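Swapping an aryl ether for a benzylamine on a shared core

The source may hold more compounds than are shown below. What is called first, only, known or untested is meant among the compounds shown, and "the series" means these compounds.

Of the compounds shown here, three built on one shared core have been tested in a functional assay on SK-MEL-5 cells (Homo sapiens) for inhibition, read by sulforhodamine B assay, with a stated time of 48 h; a lower number here means a stronger inhibitor of growth, a higher number a weaker inhibitor of growth. Compound 1 `Nc1cc(N)c2nc(-c3ccccc3)c(Oc3ccc(Cl)c(Cl)c3)nc2c1` gives 9770 nM. For the measured compounds named here, compound 3 `CCOC(=O)[C@H](CCC(=O)O)NC(=O)c1ccc(Oc2nc3cc(N)cc(N)c3nc2-c2ccccc2)cc1` gives 18200 nM, a number that sits within the usual scatter of the one for compound 1, so the two cannot be told apart. Compound 2 `COc1cc(CNc2nc3cc(N)cc(N)c3nc2-c2ccccc2)cc(OC)c1OC`, which carries a benzylamino group where the other two carry a phenoxy group, gives 724 nM, a much lower number, and its gap to compound 1 lies beyond the scatter. Compound 1 therefore stands together with compound 3 at the weak end of this small set.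

Compound 4 `Nc1cc(N)c2nc(-c3ccccc3)c(NCc3ccc(F)cc3)nc2c1` has not yet been measured. It differs from compound 1 in one place: (4-fluorobenzyl)amino in place of 3,4-dichlorophenoxy on an aromatic carbon. The change replaces the ether link with a benzylamine, moving the molecule toward the pattern seen in compound 2. Going by the values given here, no measured pair isolates this exact change, so the expectation rests on the contrast between compound 1 at 9770 nM and compound 2 at 724 nM. Compound 4 is expected to give a lower number than compound 1, a step of a 6.5-fold lower number from compound 1 to compound 4 (0.81 log units; beyond the scatter) that should lie beyond the scatter. The estimate for compound 4 in this assay is 1500 nM, with a range from 400 nM to 6000 nM.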

Compound 4, concentration for 50% growth inhibition: 1860 nM
Estimate against measurement, compound 4: 1.2-fold (0.09 log units) below; the measured number falls inside the stated range.
By their numbers in this assay, from the lowest: compound 2; then compound 4; then compounds 1 and 3 (each within the scatter of the next).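

For the compounds shown here, at this aromatic carbon, next to the ring nitrogen, putting (4-fluorobenzyl)amino in place of 3,4-dichlorophenoxy gives, in this assay, a 5.3-fold lower number from compound 1 to compound 4 (0.72 log units; beyond the scatter), the first pair in which a change at this position stands alone. The step shows that this carbon does respond to what it carries, and that a benzylamine can give a lower number here without the three methoxy groups of compound 2. Even so, the swap changes the link and the ring substituents together, and no available evidence explains the drop in the number.

The compounds shown leave open whether the step belongs to the new link or to the change in ring substituents: a (3,4-dichlorobenzyl)amino group would put the ring pattern of compound 1 on the amine link, and a 4-fluorophenoxy group would put the ring of compound 4 on the ether link. Also open, going by these compounds, is how this position responds to a longer chain, such as 2-phenylethylamino, or to a plain amino group with no ring at all.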